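Allyl for Propyl on a Benzylated Sugar Scaffold

The compounds below may be only part of what the source reports. "The series", "measured", "known", "first", "only" and "open" are said of these compounds alone.

Compound 1 `OC[C@H]1O[C@@H](Cc2ccccc2)[C@H](O)[C@@H](OCc2ccccc2)[C@@H]1OCc1ccccc1` gives 20200 nM in a functional assay on HL-60 cells (Homo sapiens) for antiproliferative activity, read by MTT assay; a higher number here means a weaker inhibitor, a lower number a stronger inhibitor.
Compound 2 `CCC[C@@H]1O[C@H](COCc2ccccc2)[C@@H](OCc2ccccc2)[C@H](OCc2ccccc2)[C@@H]1O` gives "not active" (no number reported) in this assay.
Compound 3 `CCC[C@@H]1O[C@H](COCc2ccccc2)[C@H](OCc2ccccc2)[C@H](OCc2ccccc2)[C@H]1O` gives "not active" (no number reported) in this assay.

Of the three measured compounds only compound 1 returns a number in this assay, and that number is a weak one. Compound 2 stands without a number at all: it is reported as inactive, and so is compound 3, which shares this outcome with it; the two are linked by the fact that compounds 2 and 3 differ only in the configuration as drawn. Nothing in these data separates compound 2 from compound 3 by size.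

Compound 4 `C=CC[C@@H]1O[C@H](COCc2ccccc2)[C@@H](OCc2ccccc2)[C@H](OCc2ccccc2)[C@@H]1O` is the one not yet measured. It differs from compound 2 by vinyl in place of ethyl on a saturated chain carbon bound to a saturated ring carbon. The propyl chain of compound 2 thus becomes an allyl chain, while the three benzyl ethers and the free hydroxyl on the core of compound 2 are retained. For the measured compounds named here, with no measured step of comparable kind in this set, the expectation in this assay is for no change beyond the scatter, in either direction, from the inactive result of compound 2. Compound 4 is therefore estimated at 50000 nM, with a range from 15000 nM to 150000 nM, and it is quite likely that only an inactive result, not a number, will be reported for compound 4.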

Compound 4, half-maximal inhibitory concentration: "not active" (no number reported)
Compound 4 has no reported number here; no gap can be computed for the estimate.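

In this assay compound 4, like compound 2, is reported as inactive without a number, so no step can be read for the change from propyl to allyl. Nothing available bears on this shared outcome. The compounds shown leave open whether swapping these two chains would alter activity on a core that returns a number.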